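This account rests on a few compounds, and the source may have more. Where it says the series, first, only, none or still open, it means among the compounds named here.

Compound 1 `CCOC(=O)C1=C(Nc2ccccc2)S/C(=C\c2ccccc2)C1=O`: 29.6%
Compound 2 `CCOC(=O)C1=C(Nc2cccc(C(F)(F)F)c2)S/C(=C\c2ccc[nH]2)C1=O`: 22.8%

In a functional assay on A549 cells (Homo sapiens) for inhibition, read by MTT assay, with a stated time of 72 h, tested at 10 uM (a higher number here means more inhibition at the concentration tested (going by the name of the read-out), a lower number less inhibition), compound 1 gives 29.6% and compound 2 gives 22.8%. The two values lie within the scatter of each other, so compound 1 cannot be set apart from compound 2 on these numbers. Compound 3 `CCOC(=O)C1=C(Nc2ccccc2)S/C(=C\c2cc3cccnc3[nH]2)C1=O` differs from compound 1 by a group of 9 heavy atoms (7 carbon, 2 nitrogen; one five-membered aromatic ring with 1 hetero atom, one six-membered aromatic ring with 1 hetero atom) in place of a group of 6 heavy atoms (6 carbon; one six-membered aromatic ring of carbon only), on a double-bonded chain carbon bound to a double-bonded ring carbon. Going by the values given here, no measured pair shows such a change, and nothing here points to a direction. The estimated step is a number 2.6 percentage points lower from compound 1 to compound 3 (within the scatter), no more than the scatter, and compound 3 is expected in this assay to give 27%, between 10% and 48%.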

Compound 3, a percentage reported as inhibition, at one concentration (the size of the read-out at that concentration, not a potency): 16.7%
Compound 3: middle estimate off by 10.3 percentage points, on the high side, within the range that was stated.
By their numbers in this assay, from the lowest: compounds 3, 2 and 1 (each within the scatter of the next, the first and the last beyond it).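

In this assay, replacing the phenyl on the double-bonded chain carbon with the group of two aromatic rings gives a number 12.9 percentage points lower from compound 1 to compound 3 (beyond the scatter). Going by these compounds alone, this is the first change at this place that can be read on its own, and it shows that the number responds to the group held there, though only this one replacement shows it. Nothing at hand says why the number falls. Going by these compounds, whether the lower number goes with the ring nitrogens or with the larger group stays open, as does how a methyl, a cyclohexyl or a carboxylic acid would read at this place.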